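Phenylsulfonyl tail in the oxazole ketone series

The compounds below may be only part of what the source reports. "The series", "measured", "known", "first", "only" and "open" are said of these compounds alone.

Measured compounds:
- compound 1, `O=C(CCCCCCc1ccccc1C(=O)O)c1ncc(-c2ccccn2)o1`
- compound 2, `COc1ccc(CCCCCCC(=O)c2ncc(-c3ccccn3)o2)cc1`
- compound 3, `Nc1cccc(CCCCCCC(=O)c2ncc(-c3ccccn3)o2)c1`

In an assay for inhibition of Fatty-acid amide hydrolase 1 (Rattus norvegicus) (on this read-out higher numbers stand for weaker inhibition and lower numbers for stronger inhibition), compound 1 gives > 600 nM, which is a limit of the assay and not a number. In this assay compound 2 gives 6.2 nM. Compound 3 gives 30 nM, the highest of the two numbers in hand, with compound 2 the nearest (a 4.8-fold higher number from compound 2 to compound 3 (0.68 log units; beyond the scatter)). The steps of an at least 96-fold lower number from compound 1 to compound 2 (1.98 log units; beyond the scatter) and an at least 20-fold lower number from compound 1 to compound 3 (1.30 log units; beyond the scatter) show that the group at the end of the chain moves this assay strongly, both against the limit (the limit of > 600 nM in this assay, at which 1 of the 3 values shown sits).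

Compound 4, `O=C(CCCCCS(=O)(=O)c1ccccc1)c1ncc(-c2ccccn2)o1`, differs from compound 3 as follows: phenylsulfonyl in place of 3-aminobenzyl on a saturated chain carbon, five bonds along the chain from a carbonyl carbon. Within the data shown here, none of the measured steps swaps the terminal ring for a sulfonyl-linked ring, and none shortens the chain, so the three steps give only a sense of scale: tail changes span from modest to large here. Compound 4 is expected to sit near compound 3 or somewhat higher, the step of a 2.0-fold higher number from compound 3 to compound 4 (0.30 log units; within the scatter) being the estimate. Compound 4 is therefore expected at 60 nM, with a range from 10 nM to 400 nM in this assay.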

Compound 4, inhibition constant: 6000 nM
Estimate against measurement, compound 4: 100-fold (2.00 log units) below, and the stated range ends below it.
By their numbers in this assay, from the lowest: compound 2; then compound 3; then compound 4.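

Phenylsulfonyl at this place, on a saturated chain carbon, five bonds along the chain from a carbonyl carbon, costs far more than exchanging one benzyl tail for another: a 200-fold higher number from compound 3 to compound 4 (2.30 log units; beyond the scatter) and a 970-fold higher number from compound 2 to compound 4 (2.99 log units; beyond the scatter) stand against a 4.8-fold higher number from compound 2 to compound 3 (0.68 log units; beyond the scatter) for the change from 4-methoxybenzyl to 3-aminobenzyl. Compound 4 keeps a six-membered aromatic ring of carbon only in its tail, so the presence of that ring alone does not secure a low number in this assay. Nothing shown gives a cause for this loss.

The swap in compound 4 brings in the sulfonyl link and alters the tail length at once, so a thioether link, a sulfonamide link or an unsubstituted benzyl tail would be needed to separate what each contributes. As far as these compounds go, compound 1 stays a limit, so its step to compound 4 cannot be read, and whether a carboxylic acid on the ring is worse or better than phenylsulfonyl remains open.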